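Branching in the carbamate series: compound 1 to compound 3

The source may hold more compounds than are shown below. What is called first, only, known or untested is meant among the compounds shown, and "the series" means these compounds.

Measured in a functional assay on the whole organism (strain Sprague-Dawley albino) with Rattus norvegicus as the target, in the maximal electroshock model; a higher number here means that more compound is needed for the effect, a lower number that less compound is needed:
- compound 1 `CCC(COC(N)=O)C(C)C`: 64 mg/kg
- compound 2 `CCCC(CCC)COC(N)=O`: 35 mg/kg

Compound 1 has the higher number of this pair, but compound 2 lies within the usual scatter of it, so the two cannot be ranked. Within the data shown here, no step between measured compounds that differ in one place is available.

The next compound is compound 3 `CCC(C)C(CC)COC(N)=O`, which differs from compound 1 by methyl in place of hydrogen on a saturated chain carbon, four bonds along the chain from an oxygen next to a carbonyl group. The same difference, cut one bond further out, reads isopropyl to sec-butyl.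

In this assay, no step beyond the scatter is expected. This expectation rests on compound 2 at 35 mg/kg, whose number stays within the scatter of compound 1. The estimated change is a 1.4-fold lower number from compound 1 to compound 3 (0.15 log units; within the scatter). For compound 3 the estimated value is 45 mg/kg, with an expected range of 24 mg/kg to 85 mg/kg.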

Compound 3, dose for half-maximal effect: 52 mg/kg
For compound 3 the middle estimate is 1.2-fold (0.06 log units) below the measured one; the measured number falls inside the stated range.
By their numbers in this assay, from the lowest: compounds 2, 3 and 1 (each within the scatter of the next).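

Among these compounds, the step from isopropyl to sec-butyl gives the first direct reading at this position: in this assay, methyl in place of hydrogen on a saturated chain carbon, four bonds along the chain from an oxygen next to a carbonyl group, gives a 1.2-fold lower number from compound 1 to compound 3 (0.09 log units; within the scatter). This lies within the scatter, so the position tolerates this single added methyl without a readable difference in the dose needed. No supporting measurement bears on this result.

Open, as far as these compounds go, is whether a larger group at this carbon, such as a longer chain like n-butyl, a phenyl ring or a hydroxyl group, would give a step beyond the scatter. Also open, from the compounds shown here alone, is whether the same methyl gives a comparable step on a different core.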